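The source may report more compounds than this note shows. Statements on the series, on what has been measured and on what is new or still open speak of the compounds shown alone.

Compound 2 `Cc1cc(=O)n(-c2ccc(F)cc2)nc1C(=O)Nc1ccc(Oc2ncnc3[nH]ccc23)c(F)c1` stands at the higher of the two numbers recorded so far in a functional assay on MCF7 cells (Homo sapiens) for cytotoxicity, read by MTT assay, with a stated time of 72 h (a lower number here means a stronger inhibitor, a higher number a weaker inhibitor), where compound 2 gives 24500 nM. Within the data shown here, its only measured neighbour, compound 1 `Cc1cc(=O)n(-c2ccc(F)cc2)nc1C(=O)Nc1ccc(Oc2ncnc3[nH]ccc23)cc1`, gives 4800 nM in this assay, and the one step on record, a 5.1-fold higher number from compound 1 to compound 2 (0.71 log units; beyond the scatter), is a modest loss of potency on adding a fluoro to the shared core.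

Compound 3 `Cc1ccc(-n2nc(C(=O)Nc3ccc(Oc4ncnc5[nH]ccc45)c(F)c3)c(C)cc2=O)cc1` has not yet been measured. It differs from compound 2 by methyl in place of fluoro on an aromatic carbon. Among the measured compounds shown here, this change sits on a different ring from the one altered between compound 1 and compound 2, so the single measured step offers no direct guide to its effect: swapping one small group for another of the same size at this position has no precedent among the compounds tested. With nothing in the data to favour a gain or a loss, the step of a 1.2-fold lower number from compound 2 to compound 3 (0.09 log units; within the scatter) is expected to stay within the usual scatter, and compound 3 is estimated at about 20000 nM, most likely between 6000 nM and 60000 nM.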

Compound 3, half-maximal inhibitory concentration: 18900 nM
For compound 3 the middle estimate is 1.1-fold (0.02 log units) above the measured one; the measured number falls inside the stated range.
By their numbers in this assay, from the lowest: compound 1; then compounds 3 and 2 (each within the scatter of the next).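

In this assay the change from 4-fluorophenyl to 4-methylphenyl gives a 1.3-fold lower number from compound 2 to compound 3 (0.11 log units; within the scatter) and so, on this ring and para to a large group, fluoro and methyl cannot be told apart. This is the first reading at this place, and it differs from the earlier step on the other ring, a 5.1-fold higher number from compound 1 to compound 2 (0.71 log units; beyond the scatter), which lies beyond the scatter, so among these compounds a swap involving a single heavy atom can matter at one place and show no measurable effect at another. Nothing measured here accounts for why fluoro and methyl read alike at this position.

Among these compounds, only two groups of one heavy atom each have been read at this place, so it remains open whether an amine, a carboxylic acid or a longer chain such as propyl would leave the number where it is or shift it in either direction. On these data alone, it is also open whether the 4-methylphenyl group would read the same on the core of compound 1, which lacks the second fluoro.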